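The compounds below may be only part of what the source reports. "The series", "measured", "known", "first", "only" and "open" are said of these compounds alone.

Values in a functional assay on A549 cells (Homo sapiens) for cytotoxicity, read by MTT assay, with a stated time of 48 h; on this read-out higher numbers stand for weaker inhibition and lower numbers for stronger inhibition:
- Compound 1 `COc1cc(/C=C/c2ccccc2)c(-c2ccccc2)c(OC)c1OC`: 79000 nM
- Compound 2 `C=C(c1ccc(OC)cc1)c1cc(OC)c(OC)c(OC)c1-c1ccccc1`: 22000 nM
- Compound 3 `C=C(c1ccc(C)cc1)c1cc(OC)c(OC)c(OC)c1-c1ccccc1`: 35000 nM

Compound 3 gives 35000 nM and sits with the lower pair of numbers. One measured step sets it apart: a 2.3-fold lower number from compound 1 to compound 3 (0.35 log units; beyond the scatter). The other does not: a 1.6-fold higher number from compound 2 to compound 3 (0.20 log units; within the scatter).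

The next change leads to compound 4 `C=C(c1ccc(Cl)cc1)c1cc(OC)c(OC)c(OC)c1-c1ccccc1`, with chloro in place of methyl on an aromatic carbon, para to a large group: chloro in place of methyl on an aromatic carbon. Within the data shown here, no measured step exchanges these two groups directly. The closest evidence is the exchange of methyl for methoxy in compound 3, a 1.6-fold higher number from compound 2 to compound 3 (0.20 log units; within the scatter), which involves the same ring position. The step to compound 3 from compound 1 alters the attachment of the whole aryl-ethenyl group, so it bears on this change only weakly. No step beyond the scatter is therefore expected in this assay, and neither direction is favoured by the data. The estimated step is a 1.2-fold lower number from compound 3 to compound 4 (0.07 log units; within the scatter). For compound 4 the expected value is 30000 nM, with an estimated range of 14000 nM to 65000 nM.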

Compound 4, half-maximal inhibitory concentration: 40000 nM
For compound 4 the middle estimate is 1.3-fold (0.12 log units) below the measured one; measured number inside the range.
By their numbers in this assay, from the lowest: compounds 2, 3, 4 and 1 (each within the scatter of the next, the first and the last beyond it).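

In this assay, chloro and methyl at this position, para to a large group, cannot be told apart (a 1.1-fold higher number from compound 3 to compound 4 (0.06 log units; within the scatter)), and chloro and methoxy cannot be told apart either (a 1.8-fold higher number from compound 2 to compound 4 (0.26 log units; within the scatter)), so all three groups now fall within the scatter of one another. The step from compound 1 is also within the scatter for the chloro member (a 2.0-fold lower number from compound 1 to compound 4 (0.30 log units; within the scatter)), whereas the matching step with methyl lay beyond it (a 2.3-fold lower number from compound 1 to compound 3 (0.35 log units; beyond the scatter)), so the separation from compound 1 seen earlier does not extend to compound 4. Nothing available offers an explanation for these results.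

Going by these compounds, it remains open whether any group at this position can move the number beyond the scatter, as an amine, a carboxylic acid or a longer chain would test. Also open, on these data alone, is whether the small gap between compound 1 and the 1-arylethenyl compounds would hold up on repeated measurement.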